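A methoxy-bearing ring replaces a fluorine-bearing ring

A few compounds are considered here, and "the series" means these few. Any claim that something is new, unique, unknown or untested is made for them only; others in the source may bear on it.

In a functional assay on K562 cells (Homo sapiens) for antiproliferative activity, read by MTT assay, with a stated time of 48 h (a higher number here means a weaker inhibitor, a lower number a stronger inhibitor), compound 1 `CCCCc1ccc2c(c1)C(=O)C(=O)N2` sits at the limit of > 10000 nM in this assay, at which 1 of the 3 values shown sits: its reading of > 10000 nM is a limit, not a number. Compound 2 `COc1ccc(-c2ccc3c(c2)C(=O)C(=O)N3Cc2ccc(F)cc2)cc1` gives 560 nM, the higher of the two numbers measured. Compound 3 `COc1ccc(-c2ccc3c(c2)C(=O)C(=O)N3Cc2ccc(Cl)cc2)cc1` gives 350 nM, and the step of a 1.6-fold lower number from compound 2 to compound 3 (0.20 log units; within the scatter) lies within the scatter. Compound 4 `COc1ccc(-c2ccc3c(c2)C(=O)C(=O)N3Cc2ccc(OC)c(OC)c2)cc1` has not yet been measured; it differs from compound 2 by 3,4-dimethoxyphenyl in place of 4-fluorophenyl on a saturated chain carbon bound to an amide-type nitrogen in a ring. Among the measured compounds shown here, the only measured step at this place, a 1.6-fold lower number from compound 2 to compound 3 (0.20 log units; within the scatter), changed little and says nothing about a 3,4-dimethoxyphenyl, so no step beyond the scatter is expected in either direction. Compound 4 is therefore estimated at 600 nM, within a range from 200 nM to 2000 nM. This estimate means an expected step of a 1.1-fold higher number from compound 2 to compound 4 (0.03 log units; within the scatter).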

Compound 4, half-maximal inhibitory concentration: 60 nM
Compound 4: the middle estimate sits 10-fold (1.00 log units) above what was measured; the whole stated range lies above it.
By their numbers in this assay, from the lowest: compound 4; then compounds 3 and 2 (each within the scatter of the next). At a limit, above all of these: compound 1.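

In this assay, 3,4-dimethoxyphenyl at this place gives a 9.3-fold lower number from compound 2 to compound 4 (0.97 log units; beyond the scatter) and a 5.8-fold lower number from compound 3 to compound 4 (0.77 log units; beyond the scatter). The swap from fluoro to chloro had left the number within the scatter, so only now is it clear that the ring on this saturated chain carbon can strongly change the reading. No measurement shown accounts for this gain.

On these data alone, whether a lone methoxy group on this ring would do as much remains open. So does the effect of a ring carrying an amine or a carboxylic acid at this place.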